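Removing the phenol oxygen: from compound 3 to compound 4

The source may report more compounds than this note shows. Statements on the series, on what has been measured and on what is new or still open speak of the compounds shown alone.

Measured compounds:
compound 1, `COc1cc(-n2c(-c3ccccc3)cc(/C=C3\SC(=O)NC3=O)c2-c2ccccc2)ccc1-c1ccc(/C=C2\SC(=O)NC2=O)cc1`, an assay for inhibition of glutaminase kidney isoform, mitochondrial (Homo sapiens), read by coupled enzyme assay, with stated times of 10 min and 60 min (on this read-out lower numbers stand for stronger inhibition and higher numbers for weaker inhibition), 48 nM
compound 2, `COc1cc(-n2c(C)cc(/C=C3\SC(=O)NC3=O)c2C)ccc1-c1ccc(/C=C2\SC(=O)NC2=O)cc1`, 243 nM
compound 3, `Cc1cc(/C=C2\SC(=O)NC2=O)c(C)n1-c1ccc(-c2ccc(/C=C3\SC(=O)NC3=O)cc2)c(O)c1`, 247 nM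

Compound 3 gives the highest number of the three in this assay, yet the step of a 1.0-fold higher number from compound 2 to compound 3 (0.01 log units; within the scatter) lies within the scatter, so compounds 2 and 3 cannot be told apart; compound 1 stands at a clearly lower number. Compound 4, `Cc1cc(/C=C2\SC(=O)NC2=O)c(C)n1-c1ccc(-c2ccc(/C=C3\SC(=O)NC3=O)cc2)cc1`, differs from compound 3 by hydrogen in place of hydroxy on an aromatic carbon. Among the compounds with values here, no measured step removes this oxygen outright; the only step touching the same place, a 1.0-fold higher number from compound 2 to compound 3 (0.01 log units; within the scatter), shows that changing what sits on that oxygen moved nothing beyond the scatter. Compound 4 is therefore expected to show no step beyond the scatter in this assay, a 1.0-fold higher number from compound 3 to compound 4 (0.01 log units; within the scatter). Compound 4 is estimated at 250 nM, between 100 nM and 620 nM.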

Compound 4, half-maximal inhibitory concentration: 102 nM
Beside the measured number, compound 4's estimate is 2.5-fold (0.39 log units) above it; measured number inside the range.
By their numbers in this assay, from the lowest: compound 1; then compound 4; then compounds 2 and 3 (each within the scatter of the next).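

In this assay, changing what sits on the oxygen did nothing measurable, but removing the oxygen does: hydrogen in place of hydroxy gives (a 2.4-fold lower number from compound 3 to compound 4 (0.38 log units; beyond the scatter)), and hydrogen in place of methoxy gives (a 2.4-fold lower number from compound 2 to compound 4 (0.38 log units; beyond the scatter)). At this aromatic carbon, then, the presence of the oxygen counts for more than its methyl, though both steps are modest. No available measurement accounts for this difference.

On these data alone, whether an amine or a carboxylic acid on this carbon would resemble hydrogen or hydroxy stays open. So does whether removing the methoxy from the core of compound 1 would produce a similar step.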